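The source may report more compounds than this note shows. Statements on the series, on what has been measured and on what is new or still open speak of the compounds shown alone.

Measured so far:
compound 1, `CCCc1ccc(NC(=O)N[C@@H](C)c2ccccc2)cc1`, which in an ADME assay on the whole organism with Oryza sativa as the target, tested at 0.1 uM (a lower number here means a stronger effect, a higher number a weaker effect of the compound at the concentration tested), gives 97%
compound 2, `CCCCCCCc1ccc(NC(=O)N[C@@H](C)c2ccccc2)cc1`, which in this assay gives 100%

On the two numbers shown, compound 2 sits alongside compound 1: the step of a number 3 percentage points higher from compound 1 to compound 2 (within the scatter) lies within the scatter, so neither compound stands apart from the other. The next compound, compound 3, `C[C@H](NC(=O)Nc1ccc(I)cc1)c1ccccc1`, differs from compound 2 in one place: iodo in place of heptyl on an aromatic carbon. For the measured compounds named here, no measured step bears on this change directly. Going by the values given here, the only step known, a number 3 percentage points higher from compound 1 to compound 2 (within the scatter), concerns a saturated chain carbon rather than an aromatic carbon, and it was within the scatter. Both measured compounds sit close to the top of the scale in this assay, and nothing in the data points to a shift beyond the scatter in either direction, so compound 3 is expected to stay near them, with an estimated step of a number 5 percentage points lower from compound 2 to compound 3 (within the scatter). Compound 3 is therefore estimated at 95%, within 80% to 100%.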

Compound 3, a percentage reported as activity, at one concentration (the size of the read-out at that concentration, not a potency): 99%
Compound 3: the middle estimate sits 4 percentage points below what was measured; the range from low to high includes it.
By their numbers in this assay, from the lowest: compounds 1, 3 and 2 (each within the scatter of the next).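

Compound 3 shows that on the aromatic carbon, para to a large group, iodo can take the place of heptyl with the reading in this assay staying within the scatter (a number 1 percentage points lower from compound 2 to compound 3 (within the scatter)). The same holds for iodo in place of propyl (a number 2 percentage points higher from compound 1 to compound 3 (within the scatter)), so a single iodine atom on this carbon cannot be told apart from either chain, a result the earlier step on a saturated chain carbon could not give. No measurement at hand accounts for this.

On these data alone, all three compounds sit close to the top of the scale, so it remains open whether any group on this aromatic carbon can move the number beyond the scatter. An amine, a carboxylic acid or a hydroxyl group there would be untested ground in the compounds shown.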